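The compounds below may be only part of what the source reports. "The series", "measured", "known", "first", "only" and "open" are said of these compounds alone.

Measured compounds:
compound 1, `Cc1ccc(C(=O)CC(SCC(=O)O)C(=O)O)c(C)c1`, 3830 nM
compound 2, `CCc1ccc(C(=O)CC(SCC(=O)O)C(=O)O)cc1`, 4790 nM
compound 3, `CCCCc1ccc(C(=O)CC(SCC(=O)O)C(=O)O)cc1`, 1920 nM

All three carry the same acid-bearing side chain on a six-membered aromatic ring of carbon only and were run in a functional assay on HeLa cells (Homo sapiens) for inhibition; on this read-out lower numbers stand for stronger inhibition and higher numbers for weaker inhibition. Compound 1 gives 3830 nM; its gap to compound 2 and its gap to compound 3 both lie within the scatter, so on these numbers it is not distinguishable from either. Among the measured compounds shown here, the one step beyond the scatter is a 2.5-fold lower number from compound 2 to compound 3 (0.40 log units; beyond the scatter).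

Compound 4, `Cc1ccc(C(=O)CC(SCC(=O)O)C(=O)O)c(Cl)c1`, is compound 1 with chloro in place of methyl on an aromatic carbon. For the measured compounds named here, no measured step bears on this change: the only step in hand, from compound 2 to compound 3, is a change on a saturated chain carbon, not on an aromatic carbon, and swaps neither methyl nor chloro. Within the series the aromatic substituents vary (methyl, ethyl, butyl) without a step in this assay that exceeds the scatter except the one above. Compound 4 is therefore expected to stay close to compound 1, with a 1.1-fold lower number from compound 1 to compound 4 (0.04 log units; within the scatter) not beyond the scatter. The estimate for compound 4 in this assay is 3500 nM, with a range from 1400 nM to 9000 nM.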

Compound 4, half-maximal inhibitory concentration: 4730 nM
For compound 4 the middle estimate is 1.4-fold (0.13 log units) below the measured one; low and high end bracket the measured number.
By their numbers in this assay, from the lowest: compounds 3, 1, 4 and 2 (each within the scatter of the next, the first and the last beyond it).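

In this assay, among the compounds shown here, the swap of methyl for chloro on this aromatic carbon, ortho to a large group, gives a 1.2-fold higher number from compound 1 to compound 4 (0.09 log units; within the scatter) and is the first direct reading at an aromatic carbon, since the earlier step concerned a saturated chain carbon. At this position, therefore, methyl and chloro cannot be told apart on these numbers, and compound 1 and compound 4 stand as equivalent within the scatter. Nothing available explains this outcome or gives any measured property of either group at this position.

From the compounds shown here alone, whether a larger or very different group here, such as methoxy, an amine or a longer chain, would also stay within the scatter remains open. For the compounds shown here, also open is the role of the methyl group that stays in compound 4, since no step here varies it.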